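The source may hold more compounds than are shown below. What is called first, only, known or untested is meant among the compounds shown, and "the series" means these compounds.

Measured compounds in a functional assay on MDA-MB-231 cells (Homo sapiens) for antiproliferative activity, read by MTT assay, with a stated time of 48 h; a higher number here means a weaker inhibitor, a lower number a stronger inhibitor:

Compound 1 `C/C(=C\CC/C(C)=C/CC[C@@H]1[C@@]2(C)CCC(=O)C(C)(C)[C@H]2CC[C@@]1(C)O)CC/C=C(\C)C(=O)OCc1cn(-c2ccc(C(F)(F)F)cc2)nn1` gives > 150000 nM, a limit of the assay rather than a number.
Compound 2 `C/C(=C\CC/C(C)=C/CC[C@@H]1[C@@]2(C)CCC(=O)C(C)(C)[C@H]2CC[C@@]1(C)O)CC/C=C(\C)C(=O)OCc1cn(-c2ccccc2C(F)(F)F)nn1` gives > 150000 nM, again a limit of the assay.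
Compound 3 `C/C(=C\CC/C(C)=C/CC[C@@H]1[C@@]2(C)CCC(=O)C(C)(C)[C@H]2CC[C@@]1(C)O)CC/C=C(\C)C(=O)OCc1cn(C[C@@H]2O[C@H](n3ccc(=O)[nH]c3=O)[C@H]3OC(C)(C)O[C@H]32)nn1` gives > 150000 nM, also a limit of the assay.

All three compounds share the same core, a large terpenoid ester carrying a triazole, and differ only in the group attached to the aromatic nitrogen of that triazole. None of them reached a measurable half-maximal inhibitory concentration: each value is the limit of > 150000 nM in this assay, at which 3 of the 3 values shown sit. Among the compounds with values here, because of that, the one step among them, a step that the two limits leave unreadable from compound 1 to compound 2, cannot be read as a size at all; it only shows that moving the trifluoromethyl from one position of the phenyl to another did not bring the activity into the measurable range.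

Compound 4 `C/C(=C\CC/C(C)=C/CC[C@@H]1[C@@]2(C)CCC(=O)C(C)(C)[C@H]2CC[C@@]1(C)O)CC/C=C(\C)C(=O)OCc1cn(-c2ccccc2F)nn1` has not yet been measured in this assay. It differs from compound 2 by fluoro in place of trifluoromethyl on an aromatic carbon. Within the data shown here, the only measured step that bears on this change is the unreadable one from compound 1 to compound 2, so there is no numerical guide to the size or direction of the change. For compound 4 the expected step that the limit leaves unreadable from compound 2 to compound 4 is therefore an estimate only. On the evidence of compound 2 alone, whose value is a limit, compound 4 is expected to sit near 200000 nM, with a range from 50000 nM to 600000 nM, and most likely again to be reported only as a limit.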

Compound 4, half-maximal inhibitory concentration: > 150000 nM
Compound 4: only a limit was reported; the forecaster's own chance of this, stated with the estimate: 85%; the middle value is on the limit's open side.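

Compound 4 also gives only a limit of the assay, so neither its step from compound 2 nor its step from compound 1 can be read as a size: the limit of > 150000 nM in this assay, at which 4 of the 4 values shown sit. The compounds shown leave open which group on the triazole, if any, would bring activity into the measurable range in this assay.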